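Working notes: from compound 2 to compound 3

The compounds below may be only part of what the source reports. "The series", "measured", "known", "first", "only" and "open" are said of these compounds alone.

Measured in a functional assay on HepG2 cells (Homo sapiens) for antiproliferative activity, read by sulforhodamine B assay, with a stated time of 48 h; on this read-out lower numbers stand for stronger inhibition and higher numbers for weaker inhibition:
- compound 1 `COc1cccc(/C=C/C(=O)C(=Cc2ccc(F)cc2)C(=O)/C=C/c2cccc(OC)c2OC)c1OC`: 580 nM
- compound 2 `COc1cc(C=C(C(=O)/C=C/c2cccc(OC)c2OC)C(=O)/C=C/c2cccc(OC)c2OC)ccc1O`: 200 nM

For the measured compounds named here, compound 2 gives 200 nM, the lower of the two numbers so far. The next compound to be measured is compound 3 `COc1cccc(/C=C/C(=O)C(=Cc2cc(OC)c(OC)c(OC)c2)C(=O)/C=C/c2cccc(OC)c2OC)c1OC`. It carries 3,4,5-trimethoxyphenyl in place of 4-hydroxy-3-methoxyphenyl on a double-bonded chain carbon bound to a double-bonded chain carbon.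

Going by the values given here, only one measured step bears on this change, and it lies at the same place: a 2.9-fold lower number from compound 1 to compound 2 (0.46 log units; beyond the scatter). It is modest, and it shows that the number in this assay can respond to the group at this place. Among the compounds with values here, no compound measured so far carries 3,4,5-trimethoxyphenyl there, so the direction is uncertain. Within the data shown here, with compound 2 at the low end of only two values, a small move towards a higher number is expected, no larger than the measured step. The expected step is a 1.8-fold higher number from compound 2 to compound 3 (0.24 log units; within the scatter). For compound 3 the estimate is 350 nM, with an expected range of 120 nM to 1000 nM.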

Compound 3, half-maximal inhibitory concentration: 220 nM
The estimate for compound 3 lay 1.6-fold (0.20 log units) above the measured number; the range from low to high includes it.
By their numbers in this assay, from the lowest: compounds 2 and 3 (each within the scatter of the next); then compound 1.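

In this assay, the step to 3,4,5-trimethoxyphenyl on a double-bonded chain carbon bound to a double-bonded chain carbon is a 1.1-fold higher number from compound 2 to compound 3 (0.04 log units; within the scatter), so this assay does not separate that group from 4-hydroxy-3-methoxyphenyl, even though the entering group has 0 hydrogen-bond donors and the leaving group has 1 hydrogen-bond donor. The step from 4-fluorophenyl is a 2.6-fold lower number from compound 1 to compound 3 (0.42 log units; beyond the scatter), so 4-fluorophenyl now stands apart from both oxygen-bearing groups at this place, with compound 1 beyond the scatter of compound 2 and of compound 3, and the number is shown to tolerate a larger group here, 12 heavy atoms against 9, with no step beyond the scatter. Nothing on hand gives a reason for these numbers.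

Going by these compounds, the three compounds cover only substituted phenyl groups at this place and share the rest of the core, so it remains open how the number would respond to an amine or a carboxylic acid on that ring, or to a saturated alkyl chain in place of the ring. On these data alone, with a single cell line in this assay, it also remains open whether the similarity of compound 2 and compound 3 holds in any other read-out.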